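The source may report more compounds than this note shows. Statements on the series, on what has been measured and on what is new or still open speak of the compounds shown alone.

Compound 1, `COc1cc2c(cc1OC)C(CC(=O)O)CC2`, in a functional assay on the whole organism (strain Swiss albino) for inhibition, with Mus musculus as the target, in the writhing test, with stated times of 60 min and 15 min, at a dose of 100 mg/kg by the oral route; on this read-out lower numbers stand for less inhibition and higher numbers for more inhibition at the one dose given (going by the name of the read-out): 44%
Compound 2, `COc1cc2c(cc1OC)C(CC(=O)NC(C)C)CC2`: 29.3%
Compound 3, `CCCCNC(=O)CC1CCc2cc(OC)c(OC)cc21`: 39.4%

Compound 3 holds the second highest of these three numbers. Its nearest neighbour is compound 1, and the step of a number 4.6 percentage points lower from compound 1 to compound 3 (within the scatter) stays within the scatter, so the two cannot be told apart. Its furthest neighbour is compound 2, and the step of a number 10.1 percentage points higher from compound 2 to compound 3 (beyond the scatter) is modest but beyond the scatter.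

Compound 4, `COc1cc2c(cc1OC)C(CC(=O)NCCO)CC2`, has not yet been measured. The change from compound 3 is hydroxy in place of ethyl on a saturated chain carbon, two bonds along the chain from an amide-type nitrogen. Among the compounds with values here, the only step that alters the group on the amide-type nitrogen is a number 10.1 percentage points higher from compound 2 to compound 3 (beyond the scatter), a modest shift. The steps of a number 14.7 percentage points lower from compound 1 to compound 2 (beyond the scatter) and a number 4.6 percentage points lower from compound 1 to compound 3 (within the scatter) change the carbonyl carbon, not the chain, so they bear only loosely on this case. Within the data shown here, no measured compound carries a hydroxy on that chain, so the direction is uncertain and a change of modest size at most is expected in this assay.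

Compound 4 is expected to give about 35%, between 22% and 48%. This means an expected step of a number 4.4 percentage points lower from compound 3 to compound 4 (within the scatter).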

Compound 4, a percentage reported as inhibition, in the whole organism at one dose (the size of the read-out at that dose, not a potency): 29.8%
Compound 4: middle estimate off by 5.2 percentage points, on the high side; the measured number falls inside the stated range.
By their numbers in this assay, from the lowest: compounds 2, 4, 3 and 1 (each within the scatter of the next, the first and the last beyond it).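

In this assay the step of a number 9.6 percentage points lower from compound 3 to compound 4 (within the scatter) stays within the scatter, so hydroxy in place of ethyl at this chain position gives no difference that can be told apart. The step of a number 0.5 percentage points higher from compound 2 to compound 4 (within the scatter) is also within the scatter, so the 2-hydroxyethyl and isopropyl groups on the amide nitrogen cannot be separated, while the step of a number 14.2 percentage points lower from compound 1 to compound 4 (beyond the scatter) is modest but beyond the scatter, which sets compound 4 apart from the acid, compound 1, as compound 2 is and compound 3 is not. No measurement is available that would explain these steps.

From the compounds shown here alone, it remains open how an amine or a methoxy at the end of this chain would read in this assay. A hydroxy carried on a longer chain also remains untested among these compounds, so the effect of moving it further from the amide nitrogen is unknown.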